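This account rests on a few compounds, and the source may have more. Where it says the series, first, only, none or still open, it means among the compounds named here.

Working notes on the series. In an assay for inhibition of Polyunsaturated fatty acid 5-lipoxygenase (Rattus norvegicus) (a higher number here means a weaker inhibitor, a lower number a stronger inhibitor), compound 1 `C=CCc1cc2c(cc1O)CC(CCc1ccccc1)O2` gives 17 nM. Compound 2 `O=C(O)c1ccc(OCCCc2cc3c(cc2O)CC(CCc2ccccc2)O3)cc1` holds the higher of the two numbers recorded so far: in this assay compound 2 gives 44 nM, and its gap to compound 1 lies beyond the usual scatter of the measurement. Compound 3 `Oc1cc2c(cc1CCCSc1ccncc1)OC(CCc1ccccc1)C2` is not yet measured and differs from compound 2 in one place: (pyridin-4-yl)sulfanyl in place of 4-carboxyphenoxy on a saturated chain carbon, three bonds along the chain from an aromatic carbon. For the measured compounds named here, no step between measured compounds covers a change of this kind, so nothing in the recorded numbers fixes its size or its direction. The working expectation is a step of modest size at most, with the direction open, so that the estimated step of a 1.1-fold lower number from compound 2 to compound 3 (0.04 log units; within the scatter) stays close to no change beyond the scatter. On that basis compound 3 is expected to give about 40 nM in this assay, within an estimated range from 10 nM to 160 nM.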

Compound 3, half-maximal inhibitory concentration: 8 nM
For compound 3 the middle estimate is 5.0-fold (0.70 log units) above the measured one; the measured number lies below the stated range.
By their numbers in this assay, from the lowest: compound 3; then compound 1; then compound 2.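

In this assay, the saturated chain carbon three bonds along the chain from an aromatic carbon responds to the group it carries: with (pyridin-4-yl)sulfanyl in place of 4-carboxyphenoxy, the record shows a 5.5-fold lower number from compound 2 to compound 3 (0.74 log units; beyond the scatter). The longer 2-((pyridin-4-yl)sulfanyl)ethyl in place of vinyl also gives a step beyond the scatter, a 2.1-fold lower number from compound 1 to compound 3 (0.33 log units; beyond the scatter), so a chain of this length does not cost inhibition in this pair. Nothing on record accounts for either step.

The change swaps the ring and the linking atom together, so the compounds shown do not separate the pyridine nitrogen from the sulfur. A phenylsulfanyl or a (pyridin-4-yl)oxy group on the same chain would separate them, and a longer chain would test the chain length.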